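Epimer at the ring carbon of compound 1

A few compounds are considered here, and "the series" means these few. Any claim that something is new, unique, unknown or untested is made for them only; others in the source may bear on it.

Compound 1 `CC(C)[C@@H](c1ccc(-c2ccc3cccc(F)c3c2)[nH]c1=O)[C@@H]1OC(=O)NC1=O` gives 610 nM in a functional assay on CHO cells for antagonist activity at prostaglandin E2 receptor EP3 subtype (Homo sapiens), read by cAMP accumulation, with a stated time of 30 min (a higher number here means a weaker inhibitor, a lower number a stronger inhibitor), the highest of the two numbers recorded. Compound 2 `CC(C)C(c1ccc(-c2ccc3cccc(F)c3c2)[nH]c1=O)C1C(=O)NC(=O)N1C` gives 320 nM in this assay, and the two values lie within the scatter of each other, so no order between them is claimed. Compound 3 `CC(C)[C@@H](c1ccc(-c2ccc3cccc(F)c3c2)[nH]c1=O)[C@H]1OC(=O)NC1=O` is the epimer: the two compounds have the same atoms and bonds and differ only in configuration as drawn: 1 of 2 stereo elements differ; a stereocentre at a saturated ring carbon is drawn S in compound 1 and R in compound 3. Going by the values given here, no measured pair shows what turning this stereocentre does, so the direction of the step is open and its size could be anything from none beyond the scatter to large. Compound 3 is expected near 400 nM in this assay, between 80 nM and 2500 nM, a step of a 1.5-fold lower number from compound 1 to compound 3 (0.18 log units; within the scatter) from compound 1 as an estimate only.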

Compound 3, half-maximal inhibitory concentration: 92 nM
The estimate for compound 3 lay 4.3-fold (0.64 log units) above the measured number; the range from low to high includes it.
By their numbers in this assay, from the lowest: compound 3; then compounds 2 and 1 (each within the scatter of the next).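

In this assay, turning the stereocentre at the saturated ring carbon from S to R gives a 6.6-fold lower number from compound 1 to compound 3 (0.82 log units; beyond the scatter), the first sign that the configuration at this position matters in the series. The earlier compounds shown here could not show this, as they differ in more than one place. The step belongs to this stereocentre alone, and the ground for that is: the fact that compounds 1 and 3 differ only in the configuration as drawn

Still open, from the compounds shown here alone, is what turning the other stereocentre would do. Going by these compounds, it is also open whether a carboxylic acid in place of this ring would keep the number seen for compound 3.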